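Trimming the catechol of a styrylchromone

The source may report more compounds than this note shows. Statements on the series, on what has been measured and on what is new or still open speak of the compounds shown alone.

The three measured compounds and their values in a functional assay, in the presence of a further agent that is not named here; a higher number here means a weaker inhibitor, a lower number a stronger inhibitor:

compound 1, `O=c1cc(/C=C/c2ccc(O)cc2)oc2cc(O)cc(O)c12`, 1210 nM
compound 2, `O=c1cc(/C=C/c2ccc(O)c(O)c2)oc2cccc(O)c12`, 510 nM
compound 3, `O=c1cc(/C=C/c2ccccc2)oc2cc(O)cc(O)c12`, 40600 nM

Compound 2 stands lowest of the three in this assay, strongest of the set, with compound 1 nearest and compound 3 furthest. The new compound 4, `O=c1cc(/C=C/c2ccc(O)cc2)oc2cccc(O)c12`, keeps the core of compound 2 and changes it in one place: hydrogen in place of hydroxy on an aromatic carbon.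

Among the compounds with values here, one measured step bears on this. Removing a hydroxy group from the same six-membered ring of carbon only gave a 34-fold higher number from compound 1 to compound 3 (1.53 log units; beyond the scatter), a large loss. Within the data shown here, there the hydroxy removed was the only one on that ring; here compound 4 still carries a hydroxy group on it, so a smaller loss is expected, in the same direction. The step from compound 2 to compound 4 is estimated as a 2.9-fold higher number from compound 2 to compound 4 (0.47 log units; beyond the scatter). Compound 4 is therefore expected at 1500 nM, with a range from 500 nM to 4500 nM in this assay.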

Compound 4, half-maximal inhibitory concentration: 980 nM
Estimate against measurement, compound 4: 1.5-fold (0.18 log units) above; the range from low to high includes it.
By their numbers in this assay, from the lowest: compounds 2, 4 and 1 (each within the scatter of the next, the first and the last beyond it); then compound 3.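

In this assay, the hydroxy group ortho to a hydroxy group can be lost with no clear effect, a step of a 1.9-fold higher number from compound 2 to compound 4 (0.28 log units; within the scatter). A hydroxy group on the other aromatic ring can be lost with no clear effect as well, a step of a 1.2-fold lower number from compound 1 to compound 4 (0.09 log units; within the scatter). Losing a hydroxy group is therefore not equally costly on every core, and among these compounds the large loss appears only where the ring is left with no hydroxy group at all: the same change on two cores in this assay, a 34-fold higher number (1.53 log units; beyond the scatter) from compound 1 to compound 3 and a 1.9-fold higher number (0.28 log units; within the scatter) from compound 2 to compound 4, 17-fold (1.24 log units) apart, beyond the scatter of two such steps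

Within the data shown here, it remains open whether the one hydroxy group left on that ring in compound 4 could be replaced by a methoxy group or an amine. Also open, from the compounds shown here alone, is whether that hydroxy group would serve equally well at another place on the ring.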